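The source may hold more compounds than are shown below. What is called first, only, known or untested is meant among the compounds shown, and "the series" means these compounds.

Measured compounds:
- compound 1, `COc1cc2c(Oc3ccc(NC(=O)N/N=C/c4ccc(F)cc4Cl)cc3F)ccnc2cc1OCCCN1CCCCC1`: 790 nM
- compound 2, `COc1ccc(/C=N/NC(=O)Nc2ccc(Oc3ccnc4cc(OCCCN5CCC(C)CC5)c(OC)cc34)c(F)c2)cc1`: 1000 nM
- compound 3, `COc1cc2c(Oc3ccc(NC(=O)N/N=C/c4ccc([N+](=O)[O-])cc4)cc3F)ccnc2cc1OCCCN1CCC(C)CC1`: 870 nM

In a functional assay on MDA-MB-231 cells (Homo sapiens) for cytotoxicity, read by MTT assay, with a stated time of 72 h (a higher number here means a weaker inhibitor, a lower number a stronger inhibitor), compound 3 gives 870 nM. Among the three numbers this is the second highest, yet all three sit close together: the nearest is compound 1, the furthest compound 2, and both gaps are within the scatter. Going by the values given here, the one single-point step that is known, a 1.1-fold lower number from compound 2 to compound 3 (0.06 log units; within the scatter), replaced a methoxy with a nitro on an aromatic carbon and moved the number by an amount within the scatter.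

Compound 4, `COc1cc2c(Oc3ccc(NC(=O)N/N=C/c4ccc(F)cc4Cl)cc3F)ccnc2cc1OCCCN1CCC(C)CC1`, differs from compound 3 in one place: 2-chloro-4-fluorophenyl in place of 4-nitrophenyl on a carbon with a double bond to nitrogen. Among the compounds with values here, no measured step covers exactly this exchange on a shared core. Compound 1, however, already carries the 2-chloro-4-fluorophenyl group, with a piperidine in place of the 4-methylpiperidine, and in this assay compound 1 gives 790 nM, which lies within the scatter of compound 3. Within the data shown here, every change seen so far at the hydrazone end has left the number essentially where it was, and no step stands against that.

Compound 4 is therefore expected to show no step beyond the scatter, a 1.1-fold lower number from compound 3 to compound 4 (0.03 log units; within the scatter). The estimated value of compound 4 in this assay is 820 nM, with a range from 400 nM to 1700 nM.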

Compound 4, half-maximal inhibitory concentration: 1500 nM
Beside the measured number, compound 4's estimate is 1.8-fold (0.26 log units) below it; the measured number falls inside the stated range.
By their numbers in this assay, from the lowest: compounds 1, 3, 2 and 4 (each within the scatter of the next).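

Compound 4 completes a set of three aryl groups on a carbon with a double bond to nitrogen on the shared core, so this place can now be read in all three pairings: in this assay, 2-chloro-4-fluorophenyl in place of 4-nitrophenyl gives a 1.7-fold higher number from compound 3 to compound 4 (0.24 log units; within the scatter) while the same group in place of 4-methoxyphenyl gives a 1.5-fold higher number from compound 2 to compound 4 (0.18 log units; within the scatter) and neither step lies beyond the scatter, which extends what the single earlier step had shown for this place to two more exchanges. The compound also opens a second place to comparison, since methyl in place of hydrogen on a saturated ring carbon gives a 1.9-fold higher number from compound 1 to compound 4 (0.28 log units; within the scatter) and this step too stays within the scatter, although it is the largest of those shown. No measured evidence bears on these results, so nothing can be said of what lies behind them.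

What the compounds shown leave open is whether any group at either place can move the number beyond the scatter, as every step so far stays inside it. A pyridyl group on the carbon with a double bond to nitrogen, or a hydroxyl or an amine in place of the methyl on the saturated ring carbon, would test this further.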